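A few compounds are considered here, and "the series" means these few. Any claim that something is new, unique, unknown or untested is made for them only; others in the source may bear on it.

Measured so far:
- compound 1, `Fc1ccccc1CSc1nc(-c2ccc(Br)cc2)cc(-c2ccc(Br)cc2)n1`: in an assay on isolated protein for inhibition of Alpha glucosidase (Homo sapiens), read by spectrophotometry, with stated times of 15 min and 30 min (on this read-out higher numbers stand for weaker inhibition and lower numbers for stronger inhibition), compound 1 gives 19000 nM
- compound 2, `Fc1cccc(CSc2nc(-c3ccc(Br)cc3)cc(-c3ccc(Br)cc3)n2)c1`: in this assay compound 2 gives 19000 nM

Among the measured compounds shown here, compound 2 stands level with compound 1 on these numbers; the one measured step, no change at the digits printed from compound 1 to compound 2 (within the scatter), shows no change within the scatter. It moves a fluorine from one position of the phenyl to another while everything else on the shared core stays as it is.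

The next compound, compound 3, `Clc1ccc(CSc2nc(-c3ccc(Br)cc3)cc(-c3ccc(Br)cc3)n2)cc1`, differs from compound 2 by 4-chlorophenyl in place of 3-fluorophenyl on a saturated chain carbon bound to a sulfur. For the measured compounds named here, only the step from compound 1 to compound 2 bears on this, and only in part: it shows that shifting the fluorine on the ring gave no step, but it says nothing about a chlorine in place of a fluorine, and no other measured pair touches that exchange. Going by the values given here, with the one relevant step flat, no step beyond the scatter is expected from compound 2 to compound 3, estimated as no change at the digits printed from compound 2 to compound 3 (within the scatter). Compound 3 is therefore estimated at 19000 nM, with a range from 8000 nM to 45000 nM, the width reflecting the untested halogen exchange.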

Compound 3, half-maximal inhibitory concentration: 19000 nM
Compound 3: middle estimate and measured number agree at the digits printed; the measured number falls inside the stated range.
By their numbers in this assay, from the lowest: compounds 1, 2 and 3 (each within the scatter of the next).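

In this assay, the exchange of a fluorophenyl for 4-chlorophenyl on a saturated chain carbon bound to a sulfur now has a reading: no change at the digits printed from compound 2 to compound 3 (within the scatter), and no change at the digits printed from compound 1 to compound 3 (within the scatter). The earlier pair spoke only to where a fluorine sat on the ring, whereas these two steps extend the flat reading to a different halogen, so 2-fluorophenyl, 3-fluorophenyl and 4-chlorophenyl cannot be told apart at this place on these numbers. Nothing at hand offers an explanation for this flat reading.

Going by these compounds, all three groups here are halogen-bearing phenyls, so it remains open whether the reading stays level with a phenyl carrying an amine or a carboxylic acid, or with a plain phenyl, at the same place. Also open, on these data alone, is whether a longer chain in place of the single saturated chain carbon, or a change elsewhere on the shared core, would move the value beyond the scatter.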